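Compound 4 against a limit in the thio series

This account rests on a few compounds, and the source may have more. Where it says the series, first, only, none or still open, it means among the compounds named here.

Measured in an ADME assay on BCBL1 cells (Homo sapiens) for cytotoxicity, with a stated time of 7 days; a higher number here means that more compound is tolerated, a lower number that less compound is tolerated:
- compound 1 `CNc1nc(N)nc2c1ncn2/C=C1/CC1(CO)CO`: 67000 nM
- compound 2 `CC(C)Sc1nc(N)nc2c1ncn2/C=C1/CC1(CO)CO`: > 20000 nM (a limit)
- compound 3 `Nc1nc(SC2CCCC2)c2ncn(/C=C3/CC3(CO)CO)c2n1`: > 20000 nM (a limit)

Compound 3 stands at > 20000 nM, which is a limit and not a number. It is one of the two compounds at the limit of > 20000 nM in this assay, at which 2 of the 3 values shown sit.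

The next change gives compound 4 `CCCCCCOc1nc(N)nc2c1ncn2/C=C1/CC1(CO)CO`, with hexyloxy in place of cyclopentylsulfanyl on an aromatic carbon. Among the compounds with values here, no measured compound carries hexyloxy, so no measured step matches this change directly.

The nearest steps are a step that the limit leaves unreadable from compound 1 to compound 3 and a step that the two limits leave unreadable from compound 2 to compound 3. Neither gives a size, and a step that the limit leaves unreadable from compound 1 to compound 2 gives none either. Within the data shown here, the only numeric anchor is compound 1 at 67000 nM.

A value near or past the limit is therefore expected in this assay, and no direction can be argued from these data. The expected step is a step that the limit leaves unreadable from compound 3 to compound 4. For compound 4 the estimated value is 30000 nM, within an expected range of 10000 nM to 90000 nM.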

Compound 4, half-maximal cytotoxic concentration: > 20000 nM
Compound 4 was reported as a limit; the forecaster's own chance of this, stated with the estimate: 50%; the middle value does not contradict the limit.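

In this assay compound 4 gives > 20000 nM as a limit and not a number. Within the data shown here, no step from compound 1, compound 2 or compound 3 to compound 4 can be read. Going by these compounds, whether hexyloxy, cyclopentylsulfanyl, isopropylsulfanyl and methylamino differ at all in tolerated concentration remains open.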